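Benzyl for Phenyl, Read Against Vero Cell Toxicity

This account rests on a few compounds, and the source may have more. Where it says the series, first, only, none or still open, it means among the compounds named here.

Four compounds share the same substituted bicyclic frame and differ in the amine attached to it and in the ring atoms of the core itself. Compound 1 `O=c1cc(NCc2ccccc2)sc2c([N+](=O)[O-])cc(C(F)(F)F)cc12` carries a benzylamino group, and compound 2 `O=c1cc(Nc2ccccc2)sc2c([N+](=O)[O-])cc(C(F)(F)F)cc12` an anilino group, on a core that the third and fourth compounds do not share. Compound 3 `O=c1nc(Nc2ccccc2)oc2c([N+](=O)[O-])cc(C(F)(F)F)cc12` is the anilino analogue on the second core, and compound 4 `O=c1nc(NCc2ccccc2)oc2c([N+](=O)[O-])cc(C(F)(F)F)cc12` is its benzylamino counterpart; how the two cores differ is not broken down here. Each was, or is to be, tested in an ADME assay on Vero cells (Chlorocebus sabaeus) for cytotoxicity, read by MTT assay, with a stated time of 48 h; a higher number here means a weaker inhibitor, a lower number a stronger inhibitor.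

In this assay compound 1 reaches only a limit, > 64 ug/mL. Compound 2 likewise reaches only a limit, > 64 ug/mL. Among the measured compounds shown here, compound 3 gives 37.9 ug/mL, the one numeric value among the three. The change from compound 2 to compound 1, (benzyl in place of phenyl on a nitrogen on an aromatic ring), gives a step that the two limits leave unreadable from compound 2 to compound 1; the two limits leave its size unreadable, as the limit of > 64 ug/mL in this assay, at which 2 of the 3 values shown sit, shows, since both sit at the upper bound.

The change from compound 3 to compound 4 is benzyl in place of phenyl on a nitrogen on an aromatic ring, the same kind of change made at the same kind of place. Compound 4 is therefore expected to sit near 55 ug/mL, within 25 ug/mL to 120 ug/mL. For the measured compounds named here, the expected step is a 1.5-fold higher number from compound 3 to compound 4 (0.16 log units; within the scatter), a small one, resting on the single measured instance, whose size is unreadable from the limits.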

Compound 4, half-maximal inhibitory concentration: 25.4 ug/mL
Compound 4: the middle estimate sits 2.2-fold (0.34 log units) above what was measured; low and high end bracket the measured number.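

In this assay, on the core of compound 3, benzyl in place of phenyl gives a 1.5-fold lower number from compound 3 to compound 4 (0.17 log units; within the scatter), so on this core the change from anilino to benzylamino stays within what repeated measurements would scatter. The same change on the core of compound 1 and compound 2 cannot be read, because both of those values are limits of the assay and not numbers: the limit of > 64 ug/mL in this assay, at which 2 of the 4 values shown sit. The series therefore offers one readable instance of this change rather than two, and that instance shows only a step within the scatter on a single core; it shows neither that the step carries over from one core to the other nor that it fails to do so.

The compounds shown leave open how a phenethyl or a cyclohexyl group on that same nitrogen would read against anilino and benzylamino on either core. They also leave open whether a simple alkyl amine in that place, or an amine in place of the nitro group, would bring the core of compound 1 to a readable number, which a comparison of the two cores would need.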